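The source may report more compounds than this note shows. Statements on the series, on what has been measured and on what is new or still open speak of the compounds shown alone.

Measured so far in an assay on microsomes from intestine for inhibition of acyl-CoA:cholesterol acyltransferase (Oryctolagus cuniculus); on this read-out higher numbers stand for weaker inhibition and lower numbers for stronger inhibition:
compound 1 `CCCCCCCCCCC(C)OC(=O)CC(=O)Nc1c(C(C)C)cccc1C(C)C`: 6 nM
compound 2 `CC(C)c1cccc(C(C)C)c1OC(=O)CC(=O)Nc1ccccc1`: > 5000 nM, a limit of the assay rather than a number
compound 3 `CCCCCCCCOC(=O)CC(=O)Nc1c(C(C)C)cccc1C(C)C`: 260 nM

Of the two numbers available, compound 3 stands highest; its nearest neighbour is compound 1, whose lower number lies beyond the scatter. Compound 2 gave only a limit (the limit of > 5000 nM in this assay, at which 1 of the 3 values shown sits). Among the measured compounds shown here, no two measured compounds differ in a single place, so no measured step is at hand, and the series offers no direct reading on the ester chain.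

Compound 4 `CCOC(=O)CC(=O)Nc1c(C(C)C)cccc1C(C)C` differs from compound 3 by hydrogen in place of hexyl on a saturated chain carbon, two bonds along the chain from an oxygen next to a carbonyl group. For the measured compounds named here, both numbers known so far, compound 1 and compound 3, belong to esters with long chains; compound 4 would be the first with a short one. The expectation for this assay is a rise, that is weaker inhibition, with a step from compound 3 to compound 4 estimated at a 12-fold higher number from compound 3 to compound 4 (1.06 log units; beyond the scatter). Compound 4 is thus expected near 3000 nM, within 800 nM to 15000 nM, and a limit rather than a number is a real possibility.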

Compound 4, half-maximal inhibitory concentration: 1800 nM
Compound 4: middle estimate off by 1.7-fold (0.22 log units), on the high side; the measured number falls inside the stated range.
By their numbers in this assay, from the lowest: compound 1; then compound 3; then compound 4. At a limit, above all of these: compound 2.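

In this assay the ester chain now has its first measured step: hydrogen in place of hexyl, on a saturated chain carbon two bonds along the chain from an oxygen next to a carbonyl group, gives a 6.9-fold higher number from compound 3 to compound 4 (0.84 log units; beyond the scatter), so shortening octyl to ethyl costs inhibition beyond the scatter. The larger cut, hydrogen in place of decyl, gives a 300-fold higher number from compound 1 to compound 4 (2.48 log units; beyond the scatter), and among compound 1, compound 3 and compound 4 the number rises as the chain shortens, with none of the three going against this. Nothing measured here explains either step.

An unbranched ester chain would separate length from branching in compound 1. A chain longer than that of compound 1, or an amine or a carboxylic acid at the chain end, would show how far this position tolerates change.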